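Moving a Fluorine Around a Ring on a Non-Toxic Core

The compounds below may be only part of what the source reports. "The series", "measured", "known", "first", "only" and "open" are said of these compounds alone.

Measured so far:
Compound 1 `O=C(Nc1ccc(F)c(-c2nc3ncc(-c4cc(F)ccc4F)cc3[nH]2)c1)N1CCCC1`: > 50000 nM
Compound 2 `O=C(Nc1ccc(F)c(-c2nc3ncc(-c4cncc(F)c4)cc3[nH]2)c1)N1CCCC1`: > 50000 nM
Compound 3 `O=C(Nc1ccc(F)c(-c2nc3ncc(-c4ccc(O)cc4)cc3[nH]2)c1)N1CCCC1`: > 50000 nM

In an ADME assay on HepG2 cells (Homo sapiens) for cytotoxicity, read by resazurin assay, with a stated time of 48 h (on this read-out higher numbers stand for an effect only at larger amounts of compound and lower numbers for an effect already at smaller amounts), compound 1 gives > 50000 nM, which is a limit of the assay rather than a number. Compound 2 likewise reaches only a limit, > 50000 nM. Compound 3 too sits at a limit, > 50000 nM. Because (the limit of > 50000 nM in this assay, at which 3 of the 3 values shown sit), no step among these three can be read: a step that the two limits leave unreadable from compound 1 to compound 2, a step that the two limits leave unreadable from compound 1 to compound 3 and a step that the two limits leave unreadable from compound 2 to compound 3 are all hidden behind the same limit. The shared core of compound 1 therefore appears untouched by changes of the aryl group at this position, at least as far as this assay can see.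

Compound 4 `O=C(Nc1ccc(F)c(-c2nc3ncc(-c4cc(F)cc(F)c4)cc3[nH]2)c1)N1CCCC1` is the next compound. Its difference from compound 1 is 3,5-difluorophenyl in place of 2,5-difluorophenyl on an aromatic carbon. The two compounds contain the same atoms, joined differently. None of the measured steps gives a readable size, so they offer no reason to expect compound 4 to leave the limit; the expected step is a step that the limit leaves unreadable from compound 1 to compound 4, none beyond the scatter. Compound 4 is therefore estimated at 70000 nM in this assay, with a range from 30000 nM to 200000 nM, and most likely it will again be reported only as a limit.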

Compound 4, half-maximal effective concentration: > 50000 nM
Compound 4: only a limit was reported; the forecaster's own chance of this, stated with the estimate: 85%; the middle value is on the limit's open side.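

In this assay compound 4 gives > 50000 nM, again a limit and not a number. Among these compounds, no step between compound 4 and compound 1, compound 2 or compound 3 can be read, because all four compounds stop at the same limit: the limit of > 50000 nM in this assay, at which 4 of the 4 values shown sit. The compounds shown leave open at what concentration, if any, these four would reach a half-maximal effect, and whether their aryl groups differ at all.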